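A few compounds are considered here, and "the series" means these few. Any claim that something is new, unique, unknown or untested is made for them only; others in the source may bear on it.

Three compounds have been measured in a functional assay on EKVX cells (Homo sapiens) for inhibition, read by sulforhodamine B assay, with a stated time of 48 h; on this read-out lower numbers stand for stronger inhibition of growth and higher numbers for weaker inhibition of growth:
compound 1 `Nc1cc(N)c2nc(-c3ccccc3)c(NCc3ccc(Cl)c(Cl)c3)nc2c1` gives 11000 nM
compound 2 `Nc1cc(N)c2nc(-c3ccccc3)c(Sc3ccc(F)cc3)nc2c1` gives 20400 nM
compound 3 `Nc1cc(N)c2nc(-c3ccccc3)c(Oc3ccc(F)cc3)nc2c1` gives 14800 nM

Compound 1 gives the lowest of the three numbers, yet compound 3 and compound 2 both lie within the scatter of it, so no separation among the three is established. Compound 4 `COc1ccc(CNc2nc3cc(N)cc(N)c3nc2-c2ccccc2)cc1OC` differs from compound 1 by 3,4-dimethoxyphenyl in place of 3,4-dichlorophenyl on a saturated chain carbon bound to a nitrogen on an aromatic ring. Going by the values given here, the only measured step, a 1.4-fold lower number from compound 2 to compound 3 (0.14 log units; within the scatter), concerns the group attached directly to the shared core, not the group on the saturated chain carbon, and it stayed within the scatter; no measured step touches the change made here. The step from compound 1 to compound 4 is therefore expected to be no change at the digits printed from compound 1 to compound 4 (within the scatter), with no direction beyond the scatter. Compound 4 is estimated at 11000 nM, with a range from 4500 nM to 27000 nM.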

Compound 4, concentration for 50% growth inhibition: 5890 nM
Compound 4: the middle estimate sits 1.9-fold (0.27 log units) above what was measured; the measured number falls inside the stated range.
By their numbers in this assay, from the lowest: compounds 4, 1, 3 and 2 (each within the scatter of the next, the first and the last beyond it).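

In this assay the exchange of 3,4-dichlorophenyl for 3,4-dimethoxyphenyl on the saturated chain carbon gives a 1.9-fold lower number from compound 1 to compound 4 (0.27 log units; within the scatter) and so stays within the scatter. Going by these compounds alone, this is the first change read at this group, and even with two hydrogen-bond acceptors entering where the leaving group had none, the pair is not separated. Nothing at hand bears on the reason for this result. Going by these compounds, whether an unsubstituted phenyl, a pyridine ring or a longer chain at this place would move the number beyond the scatter stays open. So does whether 3,4-dimethoxyphenyl would give a similar number on the sulfur or oxygen links of compound 2 and compound 3.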